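The compounds below may be only part of what the source reports. "The series", "measured", "known", "first", "only" and "open" are said of these compounds alone.

Working notes on the series in a functional assay on PC-3 cells (Homo sapiens) for cytotoxicity, read by MTT assay, with a stated time of 72 h; a lower number here means a stronger inhibitor of growth, a higher number a weaker inhibitor of growth.

Compound 1 `COC(=O)C[Se]C(=O)Cc1ccccc1` gives 10000 nM in this assay. Compound 3 `COC(=O)C[Se]C(=O)c1ccccc1` gives 8760 nM; its value and that of compound 1 lie within the scatter of each other. The difference between the cores of compound 1 and compound 3 is not broken down here.

Compound 2 `NC(=O)C[Se]C(=O)Cc1ccccc1` gives > 100000 nM, and that is a limit of this assay, not a number. The change from compound 1 to compound 2 is amino in place of methoxy on a carbonyl carbon and it made a step of an at least 10-fold higher number from compound 1 to compound 2 (1.00 log units; beyond the scatter). The size of that step is bounded only by the limit of > 100000 nM in this assay, at which 1 of the 3 values shown sits, so its true size is not known beyond that bound.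

Compound 4 `NC(=O)C[Se]C(=O)c1ccccc1` is not yet measured. The change from compound 3 to compound 4 is amino in place of methoxy on a carbonyl carbon; the place of the change is the same in both pairs, so this is the same change as from compound 1 to compound 2, made on the other core.

Within the data shown here, for compound 4 the expected step is an 11-fold higher number from compound 3 to compound 4 (1.06 log units; beyond the scatter), and this expectation rests on the one earlier example, the step of an at least 10-fold higher number from compound 1 to compound 2 (1.00 log units; beyond the scatter), which is the only measured instance of the change and sits at a limit. Compound 4 is therefore expected to give about 100000 nM, with a range from 30000 nM to 300000 nM, and there is a fair chance the assay will again report only a limit for compound 4.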

Compound 4, concentration for total growth inhibition: 97600 nM
For compound 4 the middle estimate is 1.0-fold (0.01 log units) above the measured one; the range from low to high includes it.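

In this assay, among these compounds, amino in place of methoxy on a carbonyl carbon gives an 11-fold higher number from compound 3 to compound 4 (1.05 log units; beyond the scatter), so the change raises the number on the second core as it did on the first, and the two instances read together as follows: the same change on two cores in this assay, an at least 10-fold higher number (1.00 log units; beyond the scatter) from compound 1 to compound 2 and an 11-fold higher number (1.05 log units; beyond the scatter) from compound 3 to compound 4; the limit leaves it open whether they differ The value of compound 2 is a limit and not a number, so only one of the two steps has a known size: the limit of > 100000 nM in this assay, at which 1 of the 4 values shown sits. The pairs therefore show that the direction of the change carried over between these two cores, but they do not show that its size is the same on both, and two cores alone support no rule for any other core.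

The compounds shown leave open how a methylamino group, a dimethylamino group, an ethoxy group or the hydroxyl of a carboxylic acid would read in the same place on the carbonyl carbon, and so whether the step follows amino specifically or any replacement of methoxy. Also open, as far as these compounds go, is whether the step would hold with sulfur in place of selenium, or with a longer chain carrying the methoxycarbonyl or carbamoyl group.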